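The source may report more compounds than this note shows. Statements on the series, on what has been measured and on what is new or still open speak of the compounds shown alone.

The measured compounds, all in a functional assay on HEL cells (Homo sapiens) for cytotoxicity, read by microscopy; a lower number here means that less compound is tolerated, a higher number that more compound is tolerated:

Compound 1, `CCCCCc1cc2cn([C@H]3C[C@H](O)[C@@H](CO)O3)c(=O)nc2o1`: in this assay compound 1 reaches only the limit of > 50000 nM.
Compound 2, `CCCCCCCCCCc1cc2cn([C@H]3C[C@H](O)[C@@H](CO)O3)c(=O)nc2o1`: in this assay compound 2 reaches only the limit of > 50000 nM.
Compound 3, `C=CCCCCCCc1cc2cn([C@H]3C[C@H](O)[C@@H](CO)O3)c(=O)nc2o1`: in this assay compound 3 reaches only the limit of > 200000 nM.

Compound 3 therefore stands at a limit rather than at a number, and the two other values shown are limits as well: the limit of > 200000 nM in this assay, at which 1 of the 3 values shown sits, and (the limit of > 50000 nM in this assay, at which 2 of the 3 values shown sit). Among the measured compounds shown here, none of the measured steps can be read. From compound 1 to compound 3 the step is a step that the two limits leave unreadable from compound 1 to compound 3, and from compound 2 to compound 3 it is a step that the two limits leave unreadable from compound 2 to compound 3; the step from compound 1 to compound 2 is a step that the two limits leave unreadable from compound 1 to compound 2.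

Compound 4, `C#CCCCCc1cc2cn([C@H]3C[C@H](O)[C@@H](CO)O3)c(=O)nc2o1`, differs from compound 3 by ethynyl in place of but-3-en-1-yl on a saturated chain carbon, four bonds along the chain from an aromatic carbon. For the measured compounds named here, the steps that bear on this change, those into compound 3 from compound 1 and from compound 2, are unreadable, so no step in this assay beyond the scatter in either direction can be expected; the estimated step from compound 3 to compound 4 is an at least 2.0-fold lower number from compound 3 to compound 4 (0.30 log units; that floor lies within the scatter). Compound 4 is thus expected to sit at about 100000 nM in this assay, between 40000 nM and 250000 nM, most likely reported again as a limit.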

Compound 4, minimum cytotoxic concentration: > 200000 nM
Compound 4: only a limit was reported; the forecaster's own chance of this, stated with the estimate: 85%; at least 2.0-fold (0.30 log units) between middle value and limit.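

In this assay compound 4 gives only a limit, > 200000 nM. Among the compounds shown here, no step from compound 1, compound 2 or compound 3 to compound 4 can be read. The compounds shown leave open at what concentration any of the four becomes cytotoxic to these cells, and whether the chain on the shared core alters that concentration at all.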